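The compounds below may be only part of what the source reports. "The series", "measured", "known", "first", "only" and "open" are said of these compounds alone.

Measured compounds in a toxicity assay on J774.1 cells (Mus musculus) for cytotoxicity, read by MTT assay, with a stated time of 48 h; on this read-out lower numbers stand for higher toxicity in this test and higher numbers for lower toxicity in this test:

- compound 1, `O=C(NCc1ccccc1C(=O)N[C@H](/C=C/S(=O)(=O)Oc1ccccc1)CCc1ccccc1)c1ccncc1`: for compound 1 the result is "nd" (no result reported).
- compound 2, `O=C(NCc1ccccc1C(=O)N[C@H](/C=C/S(=O)(=O)c1ccccc1)CCc1ccccc1)c1cccc(O)c1`: compound 2 gives 36000 nM.
- compound 3, `O=C(NCc1ccccc1C(=O)N[C@H](/C=C(\F)S(=O)(=O)Oc1ccccc1)CCc1ccccc1)c1ccc2c(c1)OCCO2`: compound 3 is reported only as an assay limit, > 100000 nM.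

For the measured compounds named here, compound 2 therefore stands as the sole numeric value in this assay ; beside it there is one limit and one entry without a result. Going by the values given here, no pair of measured compounds differs in a single place, so no measured step sizes the effect of any one change. The only further point of reference is the limit of > 100000 nM in this assay, at which 1 of the 3 values shown sits.

Compound 4, `O=C(O)c1cccc(C(=O)NCc2ccccc2C(=O)N[C@H](/C=C/S(=O)(=O)c2ccccc2)CCc2ccccc2)c1`, differs from compound 2 by carboxy in place of hydroxy on an aromatic carbon. Among the compounds with values here, with no measured step to lean on, the expected step from compound 2 to compound 4 a 1.7-fold higher number from compound 2 to compound 4 (0.22 log units; within the scatter) is a modest move toward lower toxicity, of a size that may not exceed the usual scatter. Compound 4 is accordingly estimated at 60000 nM, with a range of 20000 nM to 200000 nM, and a real chance that only a limit is reported.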

Compound 4, half-maximal cytotoxic concentration: > 100000 nM
Compound 4 ended at the assay's limit; the forecaster's own chance of this, stated with the estimate: 35%; middle value at least 1.6-fold (0.22 log units) from the limit.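

In this assay, 3-hydroxyphenyl to 3-carboxyphenyl is the only single-place change shown in the series, and it reads as an at least 2.7-fold higher number from compound 2 to compound 4 (0.44 log units; beyond the scatter), so this position on the aromatic ring does respond to the substituent, moving toward lower toxicity in this test. Compound 4 is recorded as > 100000 nM, which is a limit of the assay and not a number. The step therefore has a minimum size only, and the limit now holds a larger share of the series: the limit of > 100000 nM in this assay, at which 2 of the 4 values shown sit.

On these data alone, only hydroxy and carboxy are compared at this position, and whether an amine or a methyl ester on the same aromatic carbon would follow carboxy remains open. Also open, as far as these compounds go, is whether the same exchange gives a similar step on the core of compound 3.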